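Pyrazolyl isomer on the amide nitrogen of a thienylmethyl amide

The source may report more compounds than this note shows. Statements on the series, on what has been measured and on what is new or still open speak of the compounds shown alone.

Of the compounds shown here, three sharing one core have been measured in an assay on HEK293 cells for agonist activity at transient receptor potential cation channel subfamily M member 8 (Homo sapiens), read by fluorescence and calcium flux, with a stated time of 15 min; on this read-out higher numbers stand for an effect only at larger amounts of compound and lower numbers for an effect already at smaller amounts. Compound 3 `Cc1ccc(OCC(=O)N(C)Cc2cccs2)cc1` gives 400 nM, compound 1 `Cc1ccc(OCC(=O)N(Cc2cccs2)c2ccnn2C)cc1` gives 422 nM, and compound 2 `CCC(C)N(Cc1cccs1)C(=O)COc1ccc(C)cc1` gives 2000 nM. Compound 3 thus carries the lowest number shown, but its gap to compound 1 lies within the scatter, as a 1.1-fold lower number from compound 1 to compound 3 (0.02 log units; within the scatter) records; only compound 2 stands apart, with a 5.0-fold lower number from compound 2 to compound 3 (0.70 log units; beyond the scatter) and a 4.7-fold higher number from compound 1 to compound 2 (0.68 log units; beyond the scatter).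

Compound 4 `Cc1ccc(OCC(=O)N(Cc2cccs2)c2cnn(C)c2)cc1` has not yet been measured. It differs from compound 3 by 1-methyl-1H-pyrazol-4-yl in place of methyl on an amide-type nitrogen. The step bearing most directly on it is a 1.1-fold lower number from compound 1 to compound 3 (0.02 log units; within the scatter), in which a 1-methyl-1H-pyrazol-5-yl group in place of methyl left the number unchanged within the scatter. For the measured compounds named here, the only change that moved the number beyond the scatter, a 5.0-fold lower number from compound 2 to compound 3 (0.70 log units; beyond the scatter), concerned sec-butyl, a group absent from compound 4. Accordingly, compound 4 is expected to show a step of a 1.3-fold higher number from compound 3 to compound 4 (0.10 log units; within the scatter), essentially none beyond the scatter. For compound 4 the estimate in this assay is 500 nM, with a range from 150 nM to 1600 nM.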

Compound 4, half-maximal effective concentration: 63000 nM
Compound 4: the middle estimate sits 130-fold (2.10 log units) below what was measured; measured number above the stated range.
By their numbers in this assay, from the lowest: compounds 3 and 1 (each within the scatter of the next); then compound 2; then compound 4.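

In this assay, the amide-type nitrogen proved sensitive not only to which group it carries but also to how a pyrazole is attached, since exchanging one 1-methylpyrazolyl isomer for the other gave by far the largest change seen here (a 150-fold higher number from compound 1 to compound 4 (2.17 log units; beyond the scatter)). The earlier compounds shown here suggested that a methylpyrazolyl group could stand in for methyl at no cost, but that holds only for the 1-methyl-1H-pyrazol-5-yl group, as the 1-methyl-1H-pyrazol-4-yl group gave a large shift (a 160-fold higher number from compound 3 to compound 4 (2.20 log units; beyond the scatter)) and even exceeded the sec-butyl compound (a 32-fold higher number from compound 2 to compound 4 (1.50 log units; beyond the scatter)). Nothing available accounts for this gap between the isomers.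

The compounds shown leave open whether 1-methyl-1H-pyrazol-3-yl would track the 5-yl or the 4-yl isomer. They also leave open whether 1H-pyrazol-4-yl, lacking the methyl on its ring nitrogen, would behave like compound 4.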